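The source may report more compounds than this note shows. Statements on the series, on what has been measured and on what is new or still open speak of the compounds shown alone.

In a functional assay on MCF7 cells (Homo sapiens) for cytotoxicity, read by MTT assay, with a stated time of 96 h; a higher number here means a weaker inhibitor, a lower number a stronger inhibitor:
- Compound 1 `COc1cc(C(=O)c2cn(-c3cccc(C)c3)cc2-c2cccc([N+](=O)[O-])c2)cc(OC)c1OC`: 880 nM
- Compound 2 `COc1cc(C(=O)c2cn(-c3ccc(C)cc3)cc2-c2ccccc2Cl)cc(OC)c1OC`: 180 nM

Compound 2, at 180 nM, holds the lower of the two numbers, and the gap to compound 1 lies beyond the scatter. Compound 3 `COc1cc(C(=O)c2cn(-c3ccc(C)cc3)cc2-c2cccc([N+](=O)[O-])c2)cc(OC)c1OC` carries 3-nitrophenyl in place of 2-chlorophenyl on an aromatic carbon. For the measured compounds named here, no measured pair shows this change alone. Compound 1 also carries 3-nitrophenyl and gives 880 nM, so a weaker result is expected in this assay, with an estimated rise of a 2.8-fold higher number from compound 2 to compound 3 (0.44 log units; beyond the scatter). For compound 3 the estimated value is 500 nM, within a range of 180 nM to 1300 nM.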

Compound 3, half-maximal inhibitory concentration: 210 nM
Beside the measured number, compound 3's estimate is 2.4-fold (0.38 log units) above it; the measured number falls inside the stated range.
By their numbers in this assay, from the lowest: compounds 2 and 3 (each within the scatter of the next); then compound 1.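

In this assay, 3-nitrophenyl in place of 2-chlorophenyl gives a 1.2-fold higher number from compound 2 to compound 3 (0.07 log units; within the scatter) with the 4-methylphenyl group held fixed, so the two groups cannot be told apart at this position. The poor number of compound 1 therefore does not come with 3-nitrophenyl alone: 4-methylphenyl in place of 3-methylphenyl on the aromatic nitrogen gives a 4.2-fold lower number from compound 1 to compound 3 (0.62 log units; beyond the scatter) in the same assay, with 3-nitrophenyl kept.

From the compounds shown here alone, how an amine or a carboxylic acid would fare at this position stays open. Nothing here gives a measured reason for either step.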